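A methoxycarbonyl in place of benzyloxy

The source may report more compounds than this note shows. Statements on the series, on what has been measured and on what is new or still open speak of the compounds shown alone.

In a functional assay on HCT-116 cells (Homo sapiens) for inhibition, read by CCK-8 assay, with a stated time of 70 h (on this read-out lower numbers stand for stronger inhibition and higher numbers for weaker inhibition), compound 3 (`c1ccc(COc2ccc(COc3ccc(OCCOCCNC4CCCCC4)cc3)cc2)cc1`) gives 4350 nM and sits within the scatter of compound 2 (`Clc1ccc(COc2ccc(OCCOCCNC3CCCCC3)cc2)cc1`) at 2690 nM while compound 1 (`c1ccc(COc2ccc(OCCOCCNC3CCCC3)cc2)cc1`) gives 12900 nM and stands clearly higher, beyond the scatter of compound 3. Compound 4 (`COC(=O)c1ccc(COc2ccc(OCCOCCNC3CCCCC3)cc2)cc1`) has methoxycarbonyl in place of benzyloxy on an aromatic carbon. Going by the values given here, the one measured step at this place, a 1.6-fold higher number from compound 2 to compound 3 (0.21 log units; within the scatter) with benzyloxy in place of chloro, is small, so no step beyond the scatter is expected in this assay here. For compound 4 the estimate is 4000 nM with an expected range of 1800 nM to 9000 nM in this read-out. The estimated step is a 1.1-fold lower number from compound 3 to compound 4 (0.04 log units; within the scatter) by this reckoning.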

Compound 4, half-maximal inhibitory concentration: 5300 nM
Estimate against measurement, compound 4: 1.3-fold (0.12 log units) below; low and high end bracket the measured number.
By their numbers in this assay, from the lowest: compounds 2, 3 and 4 (each within the scatter of the next); then compound 1.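

In this assay, replacing benzyloxy on this aromatic carbon with methoxycarbonyl, a group with no ring and fewer heavy atoms, gives a 1.2-fold higher number from compound 3 to compound 4 (0.09 log units; within the scatter). Methoxycarbonyl in place of chloro gives a 2.0-fold higher number from compound 2 to compound 4 (0.29 log units; within the scatter), so chloro, benzyloxy and methoxycarbonyl, para to a large group, all lie within the scatter of one another. No measured evidence bears on this result. From the compounds shown here alone, whether a carboxylic acid or an amine at this place would stay within that range remains open.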